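Trimming the phenylpropyl chain to bare hydrogen

A few compounds are considered here, and "the series" means these few. Any claim that something is new, unique, unknown or untested is made for them only; others in the source may bear on it.

Compound 1 `CCC1(Cc2ccccc2)OS(=O)(=O)C=C1OCCCCc1ccccc1` is the reference point. In an ADME assay on HEL cells (Homo sapiens) for cytotoxicity, with a stated time of 3 days (a higher number here means that more compound is tolerated, a lower number that less compound is tolerated), compound 1 gives 99000 nM, the lowest of the two numbers shown. Its nearest neighbour is compound 3 `CCC1(Cc2ccccc2)OS(=O)(=O)CC1=O`, which in this assay gives 200000 nM. Compound 2 `CCC1(Cc2ccccc2)OS(=O)(=O)C=C1OCC(=O)OC` gives > 200000 nM in this assay, and that is a limit of the assay rather than a number. This is the same limit that the limit of > 200000 nM in this assay, at which 1 of the 3 values shown sits, describes.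

Among the measured compounds shown here, the one step that connects measured compounds, an at least 2.0-fold higher number from compound 1 to compound 2 (0.30 log units; that floor lies within the scatter), exchanges methoxycarbonyl for 3-phenylpropyl on a saturated chain carbon bound to an oxygen on an unsaturated carbon.

Compound 4 `CCC1(Cc2ccccc2)OS(=O)(=O)C=C1OC` changes the same position of compound 1: hydrogen in place of 3-phenylpropyl on a saturated chain carbon bound to an oxygen on an unsaturated carbon. The step from compound 1 to compound 2 bears on it most closely, since that step also removed the 3-phenylpropyl group from this place and moved the number upward, though only to the floor that lies within the scatter. On that basis a small rise toward the upper reach of this assay is expected, a 1.5-fold higher number from compound 1 to compound 4 (0.18 log units; within the scatter), and compound 4 is estimated at 150000 nM, with a range from 70000 nM to 300000 nM.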

Compound 4, half-maximal cytotoxic concentration: > 200000 nM
Compound 4 was reported as a limit; the forecaster's own chance of this, stated with the estimate: 35%; middle value at least 1.3-fold (0.12 log units) away from the limit.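

Hydrogen in place of 3-phenylpropyl on a saturated chain carbon bound to an oxygen on an unsaturated carbon gives an at least 2.0-fold higher number from compound 1 to compound 4 (0.30 log units; that floor lies within the scatter), the same floor that methoxycarbonyl gave, so in this assay the upward reading at this place does not depend on a replacement that brings heavy atoms of its own. The result for compound 4 is a limit of the assay, and compound 4 therefore marks the bare position with a floor and not with a number. The step between the two replacements cannot be read, because compound 2 and compound 4 both stand at the same limit, so hydrogen and methoxycarbonyl cannot be ranked against each other: the limit of > 200000 nM in this assay, at which 2 of the 4 values shown sit.

As far as these compounds go, how far the change from 3-phenylpropyl really reaches stays open, and with it whether the change lies beyond the usual scatter at all. A benzyl group, a longer chain, an amine or a carboxylic acid at this place would show whether the lower number of compound 1 belongs to 3-phenylpropyl alone.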